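The source may hold more compounds than are shown below. What is called first, only, known or untested is meant among the compounds shown, and "the series" means these compounds.

Measured compounds in a functional assay on PANC-1 cells (Homo sapiens) for inhibition, read by MTT assay, with a stated time of 24 h, tested at 10 uM; on this read-out higher numbers stand for more inhibition at the one concentration tested (going by the name of the read-out) and lower numbers for less inhibition:
compound 1 `COc1ccc(OCCCOc2cc(=O)n(CCCO)c3c2CC(C/C=C(\C)CCC=C(C)C)C(C)(C)C3)cc1` gives 20%
compound 2 `CC(C)=CCC/C(C)=C/CC1Cc2c(OCCCOc3ccc(Cl)cc3)cc(=O)n(CCCO)c2CC1(C)C` gives 25.2%
compound 3 `CC(C)=CCC/C(C)=C/CC1Cc2c(OC(=O)Nc3ccccc3F)cc(=O)n(CCCO)c2CC1(C)C` gives 71.6%

Compound 3 stands highest of the three numbers. Its nearest neighbour is compound 2, with a number 46.4 percentage points higher from compound 2 to compound 3 (beyond the scatter), and its furthest is compound 1, with a number 51.6 percentage points higher from compound 1 to compound 3 (beyond the scatter); both of these steps exchange a phenoxypropyl chain on the ring oxygen for a carbamoyl group and both lie beyond the scatter. The remaining step, a number 5.2 percentage points higher from compound 1 to compound 2 (within the scatter), exchanges chloro for methoxy on an aromatic carbon and stays within the scatter.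

Compound 4 `CC(C)=CCC/C(C)=C/CC1Cc2c(OC(=O)Nc3ccc(F)c(Cl)c3)cc(=O)n(CCCO)c2CC1(C)C` differs from compound 3 on the amide-type nitrogen: 3-chloro-4-fluorophenyl in place of 2-fluorophenyl on an amide-type nitrogen. Among the compounds with values here, no measured step alters this ring, so the change has no direct precedent. The only comparable observation is a number 5.2 percentage points higher from compound 1 to compound 2 (within the scatter), where a substituent change on an aromatic ring left the read-out within the scatter. On that basis, no step beyond the scatter is expected in this assay in either direction. Compound 4 is therefore estimated at 70%, with a range from 52% to 85%. This estimate corresponds to an expected change of a number 1.6 percentage points lower from compound 3 to compound 4 (within the scatter).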

Compound 4, a percentage reported as inhibition, at one concentration (the size of the read-out at that concentration, not a potency): 25%
Compound 4: the middle estimate sits 45 percentage points above what was measured; the measured number lies below the stated range.
By their numbers in this assay, from the lowest: compounds 1, 4 and 2 (each within the scatter of the next); then compound 3.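

In this assay, the aryl group on the amide-type nitrogen proves to be a sensitive position: 3-chloro-4-fluorophenyl in place of 2-fluorophenyl gives the largest change yet seen from a substituent change on an aromatic ring (a number 46.6 percentage points lower from compound 3 to compound 4 (beyond the scatter)), whereas chloro in place of methoxy stayed within the scatter. The carbamoyl link on the ring oxygen is therefore not enough on its own to give a high number, as the phenoxypropyl compounds and the carbamoyl compound 4 are not separated (a number 0.2 percentage points lower from compound 2 to compound 4 (within the scatter); a number 5 percentage points higher from compound 1 to compound 4 (within the scatter)), and among the four compounds only compound 3 stands apart. Nothing in the available data bears on why this ring change has such an effect.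

From the compounds shown here alone, the step alters the ring in more than one way, so it remains open whether the fall follows the added chlorine or the different fluorine placement; a plain phenyl, 4-fluorophenyl or 3-chlorophenyl group on the same nitrogen would separate these. Also open, going by these compounds, is how an amine or a carboxylic acid on this ring would read, and since each number comes from a single concentration, the series has no potency ranking yet.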